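1,1,2-Trimethylpropyl in Place of Pentan-3-yl on the Double-bonded Nitrogen

The compounds below may be only part of what the source reports. "The series", "measured", "known", "first", "only" and "open" are said of these compounds alone.

Compound 1, `CCCC(C)(C)/N=C(\NC#N)Nc1cccnc1`, gives 1 mg/kg in a functional assay on the whole organism (blood, strain Wistar-Okamoto) with Rattus norvegicus as the target, with a stated time of 5 days; a lower number here means that less compound is needed, a higher number that more compound is needed for the effect.
Compound 2, `CCC(C)(C)/N=C(\NC#N)Nc1c(C)cc(C)nc1C`, is reported only as a limit in this assay, > 25 mg/kg. This is the limit of > 25 mg/kg in this assay, at which 1 of the 3 values shown sits.
Compound 3, `CCC(CC)/N=C(\NC#N)Nc1ccncc1`, gives 2.5 mg/kg in this assay.

Of the two numbers measured in this assay, compound 3 stands at the higher one. Going by the values given here, its nearest neighbour is compound 1, whose number is lower by a margin beyond the usual scatter, while the one further value shown, that of compound 2, is a limit rather than a number. Compound 4, `CC(C)C(C)(C)/N=C(\NC#N)Nc1ccncc1`, has not yet been measured. It differs from compound 3 in a single place: 1,1,2-trimethylpropyl in place of pentan-3-yl on a double-bonded nitrogen. Among the compounds with values here, no pair of measured compounds isolates this exchange, so the expectation rests on the values as they stand. The step of a 1.7-fold lower number from compound 3 to compound 4 (0.22 log units; within the scatter) is expected to be small and downward, at the edge of the scatter, given that compound 1 reaches 1 mg/kg in this assay. Compound 4 is therefore estimated at 1.5 mg/kg, with a plausible range from 0.5 mg/kg to 5 mg/kg.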

Compound 4, minimum effective dose: 20 mg/kg
Beside the measured number, compound 4's estimate is 13-fold (1.12 log units) below it; measured number above the stated range.
By their numbers in this assay, from the lowest: compound 1; then compound 3; then compound 4. At a limit, above all of these: compound 2.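

Going by these compounds alone, the exchange of pentan-3-yl for 1,1,2-trimethylpropyl on the double-bonded nitrogen is the first single change that can be read in this assay, and it gives an 8.0-fold higher number from compound 3 to compound 4 (0.90 log units; beyond the scatter). With the rest of the molecule held fixed, the alkyl group at this place alone therefore moves the minimum effective dose by more than the scatter, and the change from one branched, ring-free group to another is not neutral. Nothing measured here accounts for the size or direction of this step.

The two compounds do not separate the effect of the added carbon from that of the different branching of the group. As far as these compounds go, how a straight pentyl chain or a cyclopentyl ring would behave at this place remains open, as does whether the same exchange would have a similar effect on the core of compound 1.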